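This account rests on a few compounds, and the source may have more. Where it says the series, first, only, none or still open, it means among the compounds named here.

Compound 2 `CN(C)Cc1cc(C(=O)/C=C/c2ccc(Cl)cc2Cl)cc(CN(C)C)c1O` stands at the lowest of the two numbers recorded in a functional assay on cells (Tumor Cell line, Homo sapiens) for cytotoxicity; a higher number here means a weaker inhibitor, a lower number a stronger inhibitor; compound 2 gives 3090 nM. Its nearest neighbour is compound 1 `CN(C)Cc1cc(C(=O)/C=C/c2ccccc2)cc(CN(C)C)c1O`, and in this assay compound 1 gives 21900 nM. Among the compounds with values here, the single step between them, a 7.1-fold lower number from compound 1 to compound 2 (0.85 log units; beyond the scatter), is the only measured guide available here.

Compound 3 `CN(C)Cc1cc(C(=O)/C=C/c2ccc(Br)cc2)cc(CN(C)C)c1O` is the next compound. It differs from compound 2 in one place: 4-bromophenyl in place of 2,4-dichlorophenyl on a double-bonded chain carbon bound to a double-bonded chain carbon. The change keeps a halogen-bearing ring on the double-bonded chain carbon, so compound 3 sits structurally between compound 1 and compound 2. Within the data shown here, the one relevant step, a 7.1-fold lower number from compound 1 to compound 2 (0.85 log units; beyond the scatter), shows that moving from phenyl to 2,4-dichlorophenyl lowered the number, and it is reasonable to expect that giving up one of the two chlorines and exchanging the other for a single bromine will hand back part of that gain in this assay, a modest rise that may well stay within the scatter. Compound 3 is therefore estimated at 6500 nM, within 2500 nM to 18000 nM, which would mean an expected step of a 2.1-fold higher number from compound 2 to compound 3 (0.32 log units; beyond the scatter).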

Compound 3, half-maximal inhibitory concentration: 6310 nM
Compound 3: the middle estimate sits 1.0-fold (0.01 log units) above what was measured; low and high end bracket the measured number.
By their numbers in this assay, from the lowest: compound 2; then compound 3; then compound 1.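

In this assay, a single bromine on the ring already lowers the number, with bromo in place of hydrogen on an aromatic carbon giving a 3.5-fold lower number from compound 1 to compound 3 (0.54 log units; beyond the scatter). A substituted ring at this position therefore does not need two chlorines for compound 3 to stand clear of the unsubstituted phenyl of compound 1. The 2,4-dichlorophenyl ring still holds a real edge over 4-bromophenyl, since the change on the double-bonded chain carbon gives a 2.0-fold higher number from compound 2 to compound 3 (0.31 log units; beyond the scatter), and the order of the three compounds is thus set by steps that all lie beyond the scatter. Nothing available explains why these rings differ from one another or from phenyl.

The swap from 2,4-dichlorophenyl to 4-bromophenyl alters both the halogen and the number of halogens on the ring, so the compounds shown cannot separate the two, and a 4-chlorophenyl ring would be the direct test of that question. The core of compound 1 also stays the same throughout, which leaves open how a methoxy group on the ring, or a cyclic amine such as morpholine in place of the dimethylamino groups, would behave in this assay.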